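The source may hold more compounds than are shown below. What is called first, only, known or untested is meant among the compounds shown, and "the series" means these compounds.

Measured so far in a physicochemical assay for lipophilicity; on this read-out higher numbers stand for higher lipophilicity and lower numbers for lower lipophilicity

Compound 1 `CCOC[C@H](Oc1ncnc2c1cnn2-c1ncccc1Cl)C(=O)Nc1ccccn1` gives 2.1
Compound 2 `Cc1cnc(NC(=O)[C@H](COC(C)C)Oc2ncnc3c2cnn3-c2ccccc2Cl)cn1` gives 2.1

In this assay compound 2 reads 2.1 and so stands level with compound 1, the two values lying within the usual scatter of repeated measurements. The next compound in the account, compound 3 `CC(C)OC[C@H](Oc1ncnc2c1cnn2-c1ccccc1Cl)C(=O)Nc1ccc(C#N)cn1`, has not yet been measured. Relative to compound 2, the change 5-cyanopyridin-2-yl in place of 5-methylpyrazin-2-yl on an amide-type nitrogen puts 5-cyanopyridin-2-yl in place of 5-methylpyrazin-2-yl on an amide-type nitrogen. Within the data shown here, the two measured compounds differ from each other in more than one place, so no measured step isolates this change, and any expectation rests on the two structures alone. What is expected is a small move in this assay, no larger than the scatter, with only a slight lean upward. The estimated step of a number 0.10 log units higher from compound 2 to compound 3 (within the scatter) therefore stays within the scatter. For compound 3 the expected value is 2.2 in an estimated range from 1.8 to 2.6 on this read-out.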

Compound 3, distribution coefficient: 3.5
The estimate for compound 3 lay 1.30 log units below the measured number; measured number outside the range, above it.
By their numbers in this assay, from the lowest: compounds 1 and 2 (each within the scatter of the next); then compound 3.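

In this assay, among these compounds, putting 5-cyanopyridin-2-yl in place of 5-methylpyrazin-2-yl on an amide-type nitrogen gives a number 1.40 log units higher from compound 2 to compound 3 (beyond the scatter), the first step in this account that isolates a single place, and it shows that this position can carry a large change on this read-out. The size of the step stands out against how little the counted features differ: the two groups have the same numbers of hydrogen-bond donors and acceptors and neither bears a net charge, so the step comes with a change in the ring's hetero atoms, the new triple bond and one more heavy atom. Nothing available here accounts for the size of this step.

The change replaces the ring and its substituent together, so the compounds shown do not tell how the step divides between the two. As far as these compounds go, a 5-methylpyridin-2-yl or a 5-cyanopyrazin-2-yl group on the same nitrogen would separate them, and whether the step holds with the ethoxy side chain of compound 1 also remains open.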